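Lengthening the side chain of compound 2

The source may hold more compounds than are shown below. What is called first, only, known or untested is meant among the compounds shown, and "the series" means these compounds.

Compound 1 `CCCOc1ccc(C(O)C2OC(=O)c3c(OC)cc(OC)cc32)cc1`: > 40000 nM
Compound 2 `COCCOc1ccc(C(O)C2OC(=O)c3c(OC)cc(OC)cc32)cc1`: > 40000 nM

Both entries come from an ADME assay on RAW264.7 cells (Mus musculus) for cytotoxicity, read by MTT assay, with a stated time of 24 h, in the presence of a further agent that is not named here; a lower number here means a stronger inhibitor, a higher number a weaker inhibitor. In this assay compound 2 gives > 40000 nM, which is a limit of the assay and not a number. That value is the limit of > 40000 nM in this assay, at which 2 of the 2 values shown sit.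

Compound 3 `COCCCOc1ccc(C(O)C2OC(=O)c3c(OC)cc(OC)cc32)cc1` carries methoxymethyl in place of methoxy on a saturated chain carbon, two bonds along the chain from an oxygen on an aromatic ring, so 2-methoxyethoxy becomes 3-methoxypropoxy (methoxymethyl in place of methoxy on a saturated chain carbon, two bonds along the chain from an oxygen on an aromatic ring).

Within the data shown here, the one measured step in this chain is a step that the two limits leave unreadable from compound 1 to compound 2. It offers no size to carry over, so no step beyond the scatter is expected in this assay, in either direction. The expected change is a step that the limit leaves unreadable from compound 2 to compound 3. For compound 3 the estimate is 50000 nM, with an expected range of 25000 nM to 100000 nM.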

Compound 3, half-maximal inhibitory concentration: > 40000 nM
Compound 3: no number, only a limit; the forecaster's own chance of this, stated with the estimate: 85%; the middle value does not contradict the limit.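

No step can be read between compound 1, compound 2 and compound 3, because each stops at the same limit of the assay and gives no number: the limit of > 40000 nM in this assay, at which 3 of the 3 values shown sit.

On these data alone, what stays open is how the three side chains compare in this assay and at what concentration, if any, each would reach half-maximal inhibition.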